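Taking the methyl off compound 3

The source may report more compounds than this note shows. Statements on the series, on what has been measured and on what is new or still open speak of the compounds shown alone.

In a functional assay on WM 266-4 cells (Homo sapiens) for antiproliferative activity, read by MTT assay, with a stated time of 24 h (a higher number here means a weaker inhibitor of growth, a lower number a stronger inhibitor of growth), compound 1 (`Fc1ccccc1C1CC(c2ccc3c(c2)OCCO3)=NN1c1ccccc1`) gives 9120 nM and compound 2 (`CSc1ccc(C2CC(c3ccc4c(c3)OCCO4)=NN2c2ccccc2)cc1`) gives 6870 nM, with a 1.3-fold lower number from compound 1 to compound 2 (0.12 log units; within the scatter) as the step that joins them. Compound 3 (`Cc1ccc(C2CC(c3ccc4c(c3)OCCO4)=NN2c2ccccc2)cc1`) gives 2530 nM as the lowest of the three numbers. Compound 4 (`c1ccc(C2CC(c3ccc4c(c3)OCCO4)=NN2c2ccccc2)cc1`) has hydrogen in place of methyl on an aromatic carbon. Among the measured compounds shown here, two measured steps bear on this change, and each ends at compound 3: a 2.7-fold lower number from compound 2 to compound 3 (0.43 log units; beyond the scatter) for methyl in place of methylsulfanyl, and a 3.6-fold lower number from compound 1 to compound 3 (0.56 log units; beyond the scatter) for 4-methylphenyl in place of 2-fluorophenyl. For the measured compounds named here, no measured compound carries hydrogen there, so a modest step toward a higher number is only an expectation. a 2.2-fold higher number from compound 3 to compound 4 (0.34 log units; beyond the scatter) is the expected step. Compound 4 is estimated at 5500 nM (expected range 2200 nM to 12000 nM).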

Compound 4, concentration for 50% growth inhibition: 22400 nM
For compound 4 the middle estimate is 4.1-fold (0.61 log units) below the measured one; measured number outside the range, above it.
By their numbers in this assay, from the lowest: compound 3; then compounds 2 and 1 (each within the scatter of the next); then compound 4.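

Hydrogen at this position gives the highest number so far: an 8.9-fold higher number from compound 3 to compound 4 (0.95 log units; beyond the scatter), a larger step than any among the earlier compounds in this assay. The other two substituted compounds also sit below the unsubstituted phenyl, with a 3.3-fold higher number from compound 2 to compound 4 (0.51 log units; beyond the scatter) and a 2.5-fold higher number from compound 1 to compound 4 (0.39 log units; beyond the scatter), so all three substituents shown give lower numbers than hydrogen, methyl by the most. Nothing available accounts for this order. On these data alone, whether any group lowers the number further than methyl stays open; an ethyl, a methoxy or an amine in this place would test that.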